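Swapping chloro for cyano on compound 2

The source may report more compounds than this note shows. Statements on the series, on what has been measured and on what is new or still open speak of the compounds shown alone.

Among the measured compounds shown here, in an ADME assay on L02 cells (Homo sapiens) for cytotoxicity, read by MTT assay, with a stated time of 24 h (a lower number here means a stronger inhibitor, a higher number a weaker inhibitor), compound 2 (`O=C1/C(=C/c2ccncc2)CN(S(=O)(=O)c2ccc(Cl)cc2)C/C1=C\c1ccccc1C(F)(F)F`) gives 14900 nM as the only exact number so far. Compound 1 (`N#Cc1ccc(S(=O)(=O)N2C/C(=C\c3ccncc3)C(=O)/C(=C/c3ccccc3F)C2)cc1`) stands at > 20000 nM as a limit of the assay, not a number. Compound 3 (`N#Cc1ccc(S(=O)(=O)N2C/C(=C\c3ccncc3)C(=O)/C(=C/c3ccccc3C(F)(F)F)C2)cc1`) differs from compound 2 in one place, with cyano in place of chloro on an aromatic carbon, para to a large group (cyano in place of chloro on an aromatic carbon). For the measured compounds named here, no measured pair shows this change alone. A small upward move in this assay, perhaps none beyond the scatter, is expected (a 1.2-fold higher number from compound 2 to compound 3 (0.08 log units; within the scatter)) for this swap. Compound 3 is estimated at 18000 nM (9000 nM to 36000 nM) in this assay.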

Compound 3, half-maximal inhibitory concentration: 17600 nM
Compound 3: the middle estimate sits 1.0-fold (0.01 log units) above what was measured, and the stated range covers the measured number.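

The swap from 4-chlorophenyl to 4-cyanophenyl gives a 1.2-fold higher number from compound 2 to compound 3 (0.07 log units; within the scatter), so compound 2 and compound 3 cannot be told apart in this assay. Trifluoromethyl in place of fluoro on an aromatic carbon gives an at least 1.1-fold lower number from compound 1 to compound 3 (0.05 log units; that floor lies within the scatter), but this step has only a floor, and compound 1 stands at a limit of the assay rather than a number: the limit of > 20000 nM in this assay, at which 1 of the 3 values shown sits.

As far as these compounds go, whether an amine or a carboxylic acid in place of cyano would move the number beyond the scatter remains open. So does the true size of the fluoro to trifluoromethyl step.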